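A few compounds are considered here, and "the series" means these few. Any claim that something is new, unique, unknown or untested is made for them only; others in the source may bear on it.

Measured compounds:
- compound 1 `Cn1c(-c2ccccc2C(F)(F)F)nnc1C12CCC(CCS(C)(=O)=O)(CC1)CC2`: in an assay on CHO-K1 cells for inhibition of 11-beta-hydroxysteroid dehydrogenase type 2 (Mus musculus), read by scintillation proximity assay (a lower number here means a stronger inhibitor, a higher number a weaker inhibitor), compound 1 gives > 4000 nM
- compound 2 `CCS(=O)(=O)CCC12CCC(c3nnc(-c4ccccc4Br)n3C)(CC1)CC2`: in this assay compound 2 gives > 4000 nM

Compound 1 sits at a limit of this assay, not at a number. Compound 2 likewise gives only a limit. Within the data shown here, both values share the limit described in the limit of > 4000 nM in this assay, at which 2 of the 2 values shown sit, so no measured step is available, and nothing yet separates one compound from the other beyond the scatter.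

Compound 3 `Cn1c(-c2ccccc2C(F)(F)F)nnc1C12CCC(COc3ccc(S(C)(=O)=O)cc3)(CC1)CC2` follows compound 1 with one change: 4-(methylsulfonyl)phenoxy in place of (methylsulfonyl)methyl on a saturated chain carbon bound to a saturated ring carbon. Among the measured compounds shown here, no pair of measured compounds shows what such a change does in this assay, so the direction is open. With compound 1 at a limit, the step from compound 1 to compound 3 is expected as an at least 1.3-fold lower number from compound 1 to compound 3 (0.12 log units; that floor lies within the scatter), with a wide range around it. Compound 3 is estimated at 3000 nM, the range running from 500 nM to 20000 nM, and a further limit-only result is well possible.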

Compound 3, half-maximal inhibitory concentration: > 4000 nM
Compound 3: only a limit was reported; the forecaster's own chance of this, stated with the estimate: 55%; middle value at least 1.3-fold (0.12 log units) away from the limit.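

In this assay compound 3 gives > 4000 nM, which is again a limit, so no step can be read between compound 1 and compound 3. The series stays unresolved: the limit of > 4000 nM in this assay, at which 3 of the 3 values shown sit.

From the compounds shown here alone, what 4-(methylsulfonyl)phenoxy in place of (methylsulfonyl)methyl does in this assay remains open, as does any ordering of compound 1, compound 2 and compound 3.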